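The source may hold more compounds than are shown below. What is called first, only, known or untested is meant among the compounds shown, and "the series" means these compounds.

Working notes on the series. Three compounds carry numbers in an assay on cells for positive allosteric modulation of Cystic fibrosis transmembrane conductance regulator variant F508del (Homo sapiens), with stated times of 10 min and 7 s, in the presence of a further agent that is not named here; a higher number here means that more compound is needed for the effect, a lower number that less compound is needed. Compound 1 `Cc1ccc(C(=O)Nc2sc3c(c2C(N)=O)CCCC3)s1` gives 652 nM. Compound 2 `CC1(C)Cc2c(sc(NC(=O)c3ccccc3O)c2C(N)=O)CO1` gives 13 nM. Compound 3 `CC1(C)Cc2c(sc(NC(=O)C(C)(C)O)c2C(N)=O)C(C)(C)O1` gives 16 nM and stands second highest of the three; its nearest neighbour is compound 2, within the scatter, and its furthest is compound 1, well beyond the scatter. Going by the values given here, no two measured compounds differ in a single place, so no isolated step can be read from what is measured.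

Compound 4 `Cc1cc(C(=O)Nc2sc3c(c2C(N)=O)CC(C)(C)OC3(C)C)[nH]n1` is not yet measured. It differs from compound 3 by 3-methyl-1H-pyrazol-5-yl in place of 1-hydroxy-1-methylethyl on a carbonyl carbon. Compound 2 shows that a ring on the carbonyl carbon next to the amide-type nitrogen is tolerated on this core, since compound 2 gives 13 nM and sits within the scatter of compound 3. For the step of a 1.4-fold higher number from compound 3 to compound 4 (0.14 log units; within the scatter) the expectation is no change beyond the scatter, with the direction, if any, towards a slightly higher number. Compound 4 is therefore expected at 22 nM, with a range from 7 nM to 70 nM.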

Compound 4, half-maximal effective concentration: 13 nM
The estimate for compound 4 lay 1.7-fold (0.23 log units) above the measured number; measured number inside the range.
By their numbers in this assay, from the lowest: compounds 2, 4 and 3 (each within the scatter of the next); then compound 1.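

In this assay, going by these compounds alone, 3-methyl-1H-pyrazol-5-yl in place of 1-hydroxy-1-methylethyl on a carbonyl carbon gives a 1.2-fold lower number from compound 3 to compound 4 (0.09 log units; within the scatter), the only step so far that isolates this position. On the core of compound 3, a group with no ring and one with a five-membered aromatic ring with 2 hetero atoms therefore read alike, although the entering group is larger by the heavy-atom counts and the hydrogen-bond donor and acceptor counts stay the same. No measurement at hand accounts for this equivalence.

As far as these compounds go, it remains open whether an amine, a carboxylic acid or a longer chain on this carbonyl carbon would read alike as well. From the compounds shown here alone, it is also open what the methyl on the pyrazole contributes, and whether the same exchange reads alike on the cores of compound 1 and compound 2.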